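The compounds below may be only part of what the source reports. "The series", "measured", "known", "first", "only" and "open" are said of these compounds alone.

Measured so far:
Compound 1, `COc1ccc(/C=C/C(=O)c2c(C)[n+]([O-])c3ccccc3[n+]2[O-])cc1`, gives 16000 nM.
Compound 2, `Cc1c(C(=O)/C=C/c2ccc(F)cc2)[n+]([O-])c2ccccc2[n+]1[O-]`, gives 4600 nM.

Both numbers come from a functional assay on HL-60 cells (Homo sapiens) for cytotoxicity, with a stated time of 48 h (on this read-out lower numbers stand for higher toxicity in this test and higher numbers for lower toxicity in this test), so compound 2, with the lower number, is the more toxic of the two in this assay. For the measured compounds named here, its nearest neighbour is compound 1, and the one measured step between them is a 3.5-fold lower number from compound 1 to compound 2 (0.54 log units; beyond the scatter). That is the full extent of what has been measured.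

Compound 3, `Cc1c(C(=O)/C=C/c2ccc(Br)cc2)[n+]([O-])c2ccccc2[n+]1[O-]`, has not yet been tested. It differs from compound 2 in a single place: bromo in place of fluoro on an aromatic carbon. Going by the values given here, no measured step covers the exchange of one halogen for another; the only step seen, from compound 1 to compound 2, concerns a different kind of change and so gives little guidance here. The expectation for this swap is therefore a small step, with no clear direction beyond the scatter.

For compound 3 the estimated value in this assay is 4000 nM, with a range from 1500 nM to 12000 nM. That estimate corresponds to an expected step of a 1.2-fold lower number from compound 2 to compound 3 (0.06 log units; within the scatter).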

Compound 3, half-maximal cytotoxic concentration: 23000 nM
Compound 3: middle estimate off by 5.8-fold (0.76 log units), on the low side; the measured number lies above the stated range.
By their numbers in this assay, from the lowest: compound 2; then compounds 1 and 3 (each within the scatter of the next).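

In this assay, exchanging one halogen for another on this aromatic carbon turns out to be far from a neutral move: the change from 4-fluorophenyl to 4-bromophenyl gives a 5.0-fold higher number from compound 2 to compound 3 (0.70 log units; beyond the scatter) and so means lower toxicity in this test. The comparison of bromo with methoxy at the same place gives a 1.4-fold higher number from compound 1 to compound 3 (0.16 log units; within the scatter) and so separates neither group from the other, which leaves fluoro as the one substituent of the three that stands out, with compound 2 the most toxic of the set. No measurement shown here bears on why fluoro behaves differently from the other two groups.

On these data alone, three groups on one aromatic carbon are too few to show a trend, so it remains open whether chloro would fall with fluoro or with bromo, and where a plain hydrogen would sit. As far as these compounds go, it is equally open whether an amine or a carboxylic acid on this carbon would match the number of compound 2 or of the other two compounds, or fall outside both.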